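This account rests on a few compounds, and the source may have more. Where it says the series, first, only, none or still open, it means among the compounds named here.

In a functional assay on SMMC-7721 cells (Homo sapiens) for antiproliferative activity, read by MTT assay, with a stated time of 48 h (on this read-out higher numbers stand for weaker inhibition and lower numbers for stronger inhibition), compound 1 (`CC(=O)OC/C1=C/C[C@](C)(CCC=C(C)C)/C=C/[C@@H](OC(=O)C=C(C)C)[C@](C)(OC(C)=O)/C=C/C1=O`) gives 4130 nM and compound 2 (`CO[C@]1(C)/C=C/C(=O)/C(CO)=C\C[C@](C)(CCC=C(C)C)/C=C/[C@H]1OC(=O)C=C(C)C`) gives 15800 nM while compound 3 (`CC(C)=CCC[C@]1(C)/C=C/[C@@H](OC(=O)C(C)C)[C@](C)(O)/C=C/C(=O)/C(CO)=C\C1`) gives 10400 nM as its reading. Compound 3 thus stands within the scatter of compound 2, and it inhibits less strongly than compound 1, a gap that lies beyond the scatter.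

Compound 4 (`COCO[C@@H]1/C=C/[C@@](C)(CCC=C(C)C)C/C=C(/CO)C(=O)/C=C/[C@@]1(C)O`) differs from compound 3 in one place, with methoxymethyl in place of isopropylcarbonyl on an oxygen on a saturated carbon. Within the data shown here, no measured pair of compounds isolates a change of this kind, so the expectation rests on compound 3 at 10400 nM as the nearest measured neighbour. In this assay only a small shift toward weaker inhibition is expected, not beyond the scatter, and the estimated move is a 1.3-fold higher number from compound 3 to compound 4 (0.13 log units; within the scatter) in size. For compound 4 the estimated value is 14000 nM with an expected range from 6000 nM to 35000 nM in this measurement.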

Compound 4, half-maximal inhibitory concentration: > 40000 nM
Compound 4: a limit, no number; the forecaster's own chance of this, stated with the estimate: 15%; at least 2.8-fold (0.45 log units) between middle value and limit.
By their numbers in this assay, from the lowest: compound 1; then compounds 3 and 2 (each within the scatter of the next). At a limit, above all of these: compound 4.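

Compound 4 reads > 40000 nM in this assay, which is a limit of the assay and not a number. Among these compounds, the exchange of isopropylcarbonyl for methoxymethyl on an oxygen on a saturated carbon gives an at least 3.8-fold higher number from compound 3 to compound 4 (0.58 log units; beyond the scatter), the first step here that isolates a single place, and it shows that the reading is sensitive to the group on this oxygen. The true size of this step stays unknown, since only its lower bound can be read: the limit of > 40000 nM in this assay, at which 1 of the 4 values shown sits.

The compounds shown leave open whether the loss follows from removing isopropylcarbonyl or from introducing methoxymethyl. They also leave open how a benzoyl group or a longer alkyl chain on this oxygen would read in this assay.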